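Fluoro to hydroxy on the dioxothian-4-yl group

The source may report more compounds than this note shows. Statements on the series, on what has been measured and on what is new or still open speak of the compounds shown alone.

Readings in an ADME assay on microsomes from liver (Mus musculus) for metabolic stability, with a stated time of 10 min (on this read-out lower numbers stand for a less stable compound and higher numbers for a more stable compound), for the series:
compound 1 `O=C([C@H]1CC[C@H](c2nnn[nH]2)CC1)N1CC[C@](c2ccc(C(F)(C(F)(F)F)C(F)(F)F)cc2)(S(=O)(=O)c2ccc(F)cc2)C1` gives 73%
compound 2 `COC(=O)[C@H]1CC[C@H](C(=O)N2CC[C@](c3ccc(C(F)(C(F)(F)F)C(F)(F)F)cc3)(S(=O)(=O)c3ccc(F)cc3)C2)CC1` is recorded as "not determined" (no result reported)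
compound 3 `O=C(N1CC[C@](c2ccc(C(F)(C(F)(F)F)C(F)(F)F)cc2)(S(=O)(=O)c2ccc(F)cc2)C1)C1(F)CCS(=O)(=O)CC1` gives 90%
compound 4 `O=C(N1CC[C@](c2ccc(C(F)(C(F)(F)F)C(F)(F)F)cc2)(S(=O)(=O)c2ccc(F)cc2)C1)C1(O)CCS(=O)(=O)CC1` is still to be measured

Of the two numbers available, compound 3 holds the higher with 90% as its reading, and the gap to compound 1 lies beyond the scatter. Compound 4 keeps everything in compound 3 except for hydroxy in place of fluoro on a saturated ring carbon, three ring bonds from the ring sulfur (hydroxy in place of fluoro on a saturated ring carbon). Among the compounds with values here, only one measured step bears on this, and only indirectly. The rise a number 17 percentage points higher from compound 1 to compound 3 (beyond the scatter) is modest and came with 4-fluoro-1,1-dioxothian-4-yl in place of 4-(1H-tetrazol-5-yl)cyclohexyl on a carbonyl carbon. Within the data shown here, that step replaces a whole group, and no measured pair isolates fluoro against hydroxy. The expectation therefore starts from compound 3 at 90% as its reference point, with the ring kept. The estimated change is a number 6 percentage points lower from compound 3 to compound 4 (within the scatter) and no step beyond the scatter is expected in this assay for this exchange. For compound 4 the estimated value is 84% with an expected range from 70% to 95% on this read-out.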

Compound 4, percent of the compound remaining: 90%
Estimate against measurement, compound 4: 6 percentage points below, and the stated range covers the measured number.
By their numbers in this assay, from the lowest: compound 1; then compounds 3 and 4 (each within the scatter of the next).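

In this assay, the exchange at this saturated ring carbon, three ring bonds from the ring sulfur, gives no change at the digits printed from compound 3 to compound 4 (within the scatter), so a hydroxy with its hydrogen-bond donor and acceptor reads no differently here from a fluoro, which has neither. The rise over the tetrazolyl cyclohexyl amide also survives the exchange, with a number 17 percentage points higher from compound 1 to compound 4 (beyond the scatter) matching a number 17 percentage points higher from compound 1 to compound 3 (beyond the scatter), which means that among these compounds the rise does not depend on the fluoro being present. No measurement at hand offers an explanation for the flat step between fluoro and hydroxy.

The series leaves open how far this ring carbon stays indifferent to its substituent, since an amine, a methoxy group, a carboxylic acid or a plain hydrogen in the same place could still separate from the pair. As far as these compounds go, it is also open whether the match between fluoro and hydroxy holds away from the 1,1-dioxothian ring, for example on the cyclohexyl ring of compound 1, or in any read-out other than this assay.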